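A few compounds are considered here, and "the series" means these few. Any claim that something is new, unique, unknown or untested is made for them only; others in the source may bear on it.

Measured compounds in a functional assay on the whole organism with Rattus norvegicus as the target, in the maximal electroshock model; a lower number here means that less compound is needed, a higher number that more compound is needed for the effect:

Compound 1, `CCNc1ncnc2c1ncn2Cc1ccccc1F`: compound 1 gives 4.9 mg/kg
Compound 2, `CC(C)Nc1ncnc2c1ncn2Cc1ccccc1F`: compound 2 gives 5.8 mg/kg
Compound 3, `Fc1ccccc1Cn1cnc2c(N3CCCC3)ncnc21`: compound 3 gives 12.5 mg/kg

Compound 3 stands at the highest of the three numbers in this assay; the nearest is compound 2 and the furthest is compound 1. The two steps that reach compound 3 both replace a secondary amine with a cyclic tertiary amine on the same aromatic carbon: a 2.6-fold higher number from compound 1 to compound 3 (0.41 log units; beyond the scatter) and a 2.2-fold higher number from compound 2 to compound 3 (0.33 log units; beyond the scatter). Between compounds 1 and 2 the change is small: a 1.2-fold higher number from compound 1 to compound 2 (0.07 log units; within the scatter).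

Compound 4, `Fc1ccccc1Cn1cnc2c(NC3CC3)ncnc21`, differs from compound 3 by cyclopropylamino in place of pyrrolidin-1-yl on an aromatic carbon. This step runs the other way from the two steps that raised the number: it restores a hydrogen-bond donor on the amine nitrogen and keeps a small carbon group on it. The steps from compound 1 and from compound 2 to compound 3 are the ones that bear on it, and both were modest and beyond the scatter. A step of about that size, in the lowering direction, is therefore expected for compound 4 in this assay: a 2.1-fold lower number from compound 3 to compound 4 (0.32 log units; beyond the scatter). The estimate for compound 4 is 6 mg/kg, with a range from 3 mg/kg to 12 mg/kg.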

Compound 4, dose for half-maximal effect: 5 mg/kg
The estimate for compound 4 lay 1.2-fold (0.08 log units) above the measured number; low and high end bracket the measured number.
By their numbers in this assay, from the lowest: compounds 1, 4 and 2 (each within the scatter of the next); then compound 3.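

In this assay, a ring on this aromatic carbon does not by itself go with the higher number: cyclopropylamino in place of pyrrolidin-1-yl gives a 2.5-fold lower number from compound 3 to compound 4 (0.40 log units; beyond the scatter), a step beyond the scatter despite the ring in the entering group. Set against the open-chain groups, cyclopropyl on the same nitrogen gives a 1.0-fold higher number from compound 1 to compound 4 (0.01 log units; within the scatter) and a 1.2-fold lower number from compound 2 to compound 4 (0.06 log units; within the scatter), so ethyl, isopropyl and cyclopropyl cannot be told apart in this series. For the compounds shown here, compounds 1, 2 and 4, each with 1 hydrogen-bond donor in this group, now form one cluster, and compound 3, with 0 hydrogen-bond donors, stands alone above it, with no compound here going against that split.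

Nothing at hand explains the gap between compound 3 and the others. The split also rests on compound 3 alone, which leaves open whether it follows the lost hydrogen-bond donor or the pyrrolidin-1-yl ring itself, a question that dimethylamino and cyclopentylamino on the same aromatic carbon would help to separate.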